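Swapping Iodo for Tert-Butyl on a Chloropropanamide

The source may report more compounds than this note shows. Statements on the series, on what has been measured and on what is new or still open speak of the compounds shown alone.

Compound 1, `CC(C)(C)c1ccc(NC(=O)CCl)cc1`: 5400 nM
Compound 2, `O=C(CCCl)Nc1ccc(I)cc1`: 20000 nM

In a functional assay on M21 cells (Homo sapiens) for antiproliferative activity, with a stated time of 48 h (a lower number here means a stronger inhibitor, a higher number a weaker inhibitor), compound 2 gives the highest of these two numbers, and compound 1 gives a lower one, a gap beyond the scatter; but the two compounds differ in two places, so that gap cannot be split into parts. Compound 3, `CC(C)(C)c1ccc(NC(=O)CCCl)cc1`, is not yet measured and differs from compound 2 by tert-butyl in place of iodo on an aromatic carbon. Within the data shown here, no single-change step between measured compounds exists to guide this, so only a modest fall in this assay is expected, not clearly beyond the scatter. Compound 3 is estimated at 12000 nM, between 4000 nM and 36000 nM, which means an expected step of a 1.7-fold lower number from compound 2 to compound 3 (0.22 log units; within the scatter).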

Compound 3, half-maximal inhibitory concentration: 74000 nM
For compound 3 the middle estimate is 6.2-fold (0.79 log units) below the measured one, and the stated range ends below it.
By their numbers in this assay, from the lowest: compound 1; then compound 2; then compound 3.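

In this assay tert-butyl in place of iodo on the aromatic carbon gives a 3.7-fold higher number from compound 2 to compound 3 (0.57 log units; beyond the scatter) on the chloropropanamide, so here iodo goes with the lower number. The chain also counts: chloromethyl in place of chloro on the saturated chain carbon bound to the carbonyl carbon gives a 14-fold higher number from compound 1 to compound 3 (1.14 log units; beyond the scatter) with tert-butyl held fixed, a large step. Nothing at hand explains why either change acts as it does.

Still open, going by these compounds, is how an amine or a methoxy group would fare on that aromatic carbon. Also open, on these data alone, is whether a longer chain would raise the number further.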